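Fluoro to phenyl on the aryl ketone of compound 1

The source may report more compounds than this note shows. Statements on the series, on what has been measured and on what is new or still open speak of the compounds shown alone.

Compound 1 `COc1cc(-c2nnc3n2NC(c2ccco2)C(C(=O)c2ccc(F)cc2)S3)cc(OC)c1OC` carries a fluoro on the aryl ketone. In a functional assay on A549 cells (Homo sapiens) for cytotoxicity, read by MTT assay, with a stated time of 48 h (a higher number here means a weaker inhibitor, a lower number a stronger inhibitor), compound 1 gives 53700 nM, the lowest of the two numbers in hand. Compound 3 `COc1cc(-c2nnc3n2NC(c2ccco2)C(C(=O)c2ccc(O)cc2)S3)cc(OC)c1OC`, with hydroxy in place of that fluoro, gives 93400 nM in this assay; the step of a 1.7-fold higher number from compound 1 to compound 3 (0.24 log units; within the scatter) stays within the scatter, so the two compounds cannot be ordered. Compound 2 `COc1cc(C(=O)C2Sc3nnc(-c4cc(OC)c(OC)c(OC)c4)n3NC2c2cccs2)cc(OC)c1OC`, the thienyl analogue with the trimethoxyphenyl ketone, gives > 100000 nM in this assay, which is a limit of the assay and not a number, the limit (the limit of > 100000 nM in this assay, at which 1 of the 3 values shown sits).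

Compound 4 `COc1cc(-c2nnc3n2NC(c2ccco2)C(C(=O)c2ccc(-c4ccccc4)cc2)S3)cc(OC)c1OC` differs from compound 1 by phenyl in place of fluoro on an aromatic carbon. For the measured compounds named here, no measured step changes this position in a comparable way: the single step in hand exchanges fluoro for hydroxy and moves the number by less than the scatter. Going by the values given here, the replacement by phenyl is a larger structural change, yet the series gives no measured step of that kind to lean on, and the numbers so far cluster in a narrow band near the upper reach of this assay.

The expectation is therefore a step of a 1.1-fold lower number from compound 1 to compound 4 (0.03 log units; within the scatter) that need not exceed the scatter in either direction. Compound 4 is estimated at 50000 nM, with a range from 15000 nM to 150000 nM, and a real chance that this assay reports only a limit.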

Compound 4, half-maximal inhibitory concentration: > 100000 nM
Compound 4 gave a limit, no number (the forecaster's own chance of this, stated with the estimate: 30%); middle value at least 2.0-fold (0.30 log units) from the limit.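

In this assay compound 4 reads > 100000 nM, which is a limit of the assay and not a number, so the much larger phenyl at this position yields no readable gain. The change gives an at least 1.8-fold higher number from compound 1 to compound 4 (0.27 log units; that floor lies within the scatter), and the exchange from the hydroxy analogue gives an at least 1.0-fold higher number from compound 3 to compound 4 (0.02 log units; that floor lies within the scatter), so neither step separates compound 4 from its partner, and the three groups at this position cannot be put in order. Changes at this position have so far brought no number clearly lower than that of compound 1, and with this result the upper end of the assay now restricts what the series can show: the limit of > 100000 nM in this assay, at which 2 of the 4 values shown sit.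

From the compounds shown here alone, it remains open whether an amine or a carboxylic acid in place of the fluoro would give a number beyond the scatter from compound 1, in either direction. Also open, going by these compounds, is how far compound 4 lies beyond its limit, and so whether 4-fluorophenyl to 4-phenylphenyl is a real loss or a change too small to read.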